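Morpholine to piperidine on the second sulfonyl group

A few compounds are considered here, and "the series" means these few. Any claim that something is new, unique, unknown or untested is made for them only; others in the source may bear on it.

Compound 2, `CCOC(=O)[C@@H]1CCCN(S(=O)(=O)c2ccc(S(=O)(=O)N3CCOCC3)cc2)C1`, is the weaker of the two compounds that gave a number in a functional assay on MIA PaCa-2 cells (Homo sapiens) for inhibition, read by MTT assay, with a stated time of 3 days; a lower number here means a stronger inhibitor, a higher number a weaker inhibitor: compound 2 gives 4100 nM. Compound 1, `CCCN(CCC)S(=O)(=O)c1ccc(S(=O)(=O)N2CCC[C@@H](C(=O)OCC)C2)cc1`, carries dipropylamino in place of the morpholin-4-yl ring and in this assay compound 1 gives 600 nM, so there was a 6.8-fold higher number from compound 1 to compound 2 (0.83 log units; beyond the scatter). Compound 3, `CCN1CC(NC(=O)[C@@H]2CCCN(S(=O)(=O)c3ccc(S(=O)(=O)N(CC)CC)cc3)C2)C1`, in this assay gives only > 10000 nM, which is a limit of the assay rather than a number (the limit of > 10000 nM in this assay, at which 1 of the 3 values shown sits).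

Compound 4, `CCOC(=O)[C@@H]1CCCN(S(=O)(=O)c2ccc(S(=O)(=O)N3CCCCC3)cc2)C1`, differs from compound 2 in one place: piperidin-1-yl in place of morpholin-4-yl on a sulfonyl sulfur. Among the compounds with values here, the only measured step at this sulfonyl sulfur is the one from compound 1 to compound 2, where a six-membered ring with two hetero atoms replaced an open dipropylamino group and the number rose by a modest amount. Compound 4 keeps a six-membered ring but, as counted, loses the oxygen and its single hydrogen-bond acceptor, so the change sits between those two cases. Compound 4 is therefore expected to give a somewhat lower number than compound 2, an estimated step of a 2.1-fold lower number from compound 2 to compound 4 (0.31 log units; beyond the scatter). Compound 4 is expected to give about 2000 nM, within a range from 700 nM to 6000 nM.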

Compound 4, half-maximal inhibitory concentration: 1000 nM
Estimate against measurement, compound 4: 2.0-fold (0.30 log units) above; measured number inside the range.
By their numbers in this assay, from the lowest: compounds 1 and 4 (each within the scatter of the next); then compound 2. At a limit, above all of these: compound 3.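

In this assay, within the data shown here, the only change from morpholin-4-yl to piperidin-1-yl on this sulfonyl sulfur is that the ring oxygen gives way to a carbon, and this gives a 4.1-fold lower number from compound 2 to compound 4 (0.61 log units; beyond the scatter), so the ring size stays the same while the number still moves beyond the scatter. The open chain and the ring can now be compared directly, with a 1.7-fold higher number from compound 1 to compound 4 (0.22 log units; within the scatter), so dipropylamino and piperidin-1-yl cannot be told apart here, and the weaker result for compound 2 does not come with ring closure as such, at least among these three esters. None of the available evidence bears on why removing the ring oxygen changes the number.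

Going by these compounds, it remains open whether a piperazin-1-yl ring, with a second nitrogen in place of the morpholine oxygen, or a five-membered pyrrolidin-1-yl ring would follow compound 2 or compound 4. On these data alone, it is also open whether the same order of sulfonyl groups would hold if the ethyl ester on the shared core were replaced by a carboxylic acid.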